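Pyrazolylphenyl amide estimated from quinolinyl analogues

The source may hold more compounds than are shown below. What is called first, only, known or untested is meant among the compounds shown, and "the series" means these compounds.

Measured compounds:
- compound 1 `CCCN(CC[C@H]1CC[C@H](NC(=O)/C=C/c2ccc(OC)cc2)CC1)[C@H]1CCc2nc(N)sc2C1`, which in an assay on brain for displacement of a labelled ligand from D(3) dopamine receptor (Rattus norvegicus) (a lower number here means a stronger inhibitor, a higher number a weaker inhibitor), gives 6.7 nM
- compound 2 `CCCN(CC[C@H]1CC[C@H](NC(=O)c2ccc3ccccc3n2)CC1)[C@H]1CCc2nc(N)sc2C1`, which in this assay gives 1.6 nM
- compound 3 `CCCN(CC[C@H]1CC[C@H](NC(=O)c2cccc3ncccc23)CC1)[C@H]1CCc2nc(N)sc2C1`, which in this assay gives 1.6 nM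

For the measured compounds named here, compound 3 stands level with compound 2, the two together giving the lowest numbers of the three; its only separation is from compound 1, as the step of a 4.2-fold lower number from compound 1 to compound 3 (0.62 log units; beyond the scatter) shows.

Compound 4 `CCCN(CC[C@H]1CC[C@H](NC(=O)c2ccc(-n3cccn3)cc2)CC1)[C@H]1CCc2nc(N)sc2C1` differs from compound 3 at the amide: 4-(1H-pyrazol-1-yl)phenyl in place of quinolin-5-yl on a carbonyl carbon

Going by the values given here, three steps bear on this change, all of them swaps of the group on the carbonyl carbon. The steps of a 4.2-fold lower number from compound 1 to compound 2 (0.62 log units; beyond the scatter) and a 4.2-fold lower number from compound 1 to compound 3 (0.62 log units; beyond the scatter) are modest and in the same direction, while the step of no change at the digits printed from compound 2 to compound 3 (within the scatter) is within the scatter. Two aromatic rings on the carbonyl have therefore given the same outcome twice, and the group entering in compound 4 also carries two aromatic rings. Among the compounds with values here, the step of a 1.6-fold higher number from compound 3 to compound 4 (0.19 log units; within the scatter) is thus expected to be small, most likely within the scatter, with a slight lean toward a higher number given that no measured example of this particular group exists. Compound 4 is estimated at 2.5 nM in this assay, within a range of 1 nM to 8 nM.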

Compound 4, inhibition constant: 3 nM
For compound 4 the middle estimate is 1.2-fold (0.08 log units) below the measured one, within the range that was stated.
By their numbers in this assay, from the lowest: compounds 2, 3 and 4 (each within the scatter of the next); then compound 1.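

In this assay, the group on the carbonyl carbon need not be a quinolinyl group to stay within the scatter of compound 2 and compound 3. The 4-(1H-pyrazol-1-yl)phenyl group, with one five-membered aromatic ring with 2 hetero atoms and one six-membered aromatic ring of carbon only, gives (a 1.9-fold higher number from compound 3 to compound 4 (0.27 log units; within the scatter)) and (a 1.9-fold higher number from compound 2 to compound 4 (0.27 log units; within the scatter)). The separation from the 2-(4-methoxyphenyl)ethenyl group of compound 1 also holds for this third group (a 2.2-fold lower number from compound 1 to compound 4 (0.35 log units; beyond the scatter)), so compound 2, compound 3 and compound 4 all lie on the same side of compound 1, and none of the four compounds goes against this. Nothing measured here accounts for this agreement among the three groups.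

The compounds shown leave open whether a single phenyl or a cyclohexyl group on the carbonyl carbon would stay level with these amides, and whether a 1H-imidazol-1-yl group in place of the 1H-pyrazol-1-yl group would do so. For the compounds shown here, they also leave open what an amine or a carboxylic acid on the phenyl ring of compound 4 would do to its number in this assay (a question no step here can answer).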